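The compounds below may be only part of what the source reports. "The series", "measured", "known", "first", "only" and "open" are said of these compounds alone.

Measured so far:
Compound 1 `O=C(CSc1nc(Nc2ccccc2)c2ccccc2n1)Nc1ccccc1F` — 10700 nM
Compound 2 `O=C(CSc1nc(Nc2ccccc2)c2ccccc2n1)Nc1cccc(Cl)c1` — 14300 nM
Compound 3 `C=CC(=O)Nc1cccc(NC(=O)CSc2nc(Nc3ccccc3F)c3ccccc3n2)c1` — 26100 nM

In a functional assay on MGC-803 cells (Homo sapiens) for inhibition, read by MTT assay, with a stated time of 72 h (on this read-out lower numbers stand for stronger inhibition and higher numbers for weaker inhibition), compound 3 has the highest of the three numbers; compound 2 sits nearest, compound 1 furthest. Compound 4 `C=CC(=O)Nc1cccc(NC(=O)CSc2nc(Nc3ccc(Br)cc3)c3ccccc3n2)c1` has not yet been measured. Its difference from compound 3 is 4-bromophenyl in place of 2-fluorophenyl on a nitrogen on an aromatic ring. Among the compounds with values here, no measured step touches that nitrogen. Within the data shown here, the only one-place step on record, a 1.3-fold higher number from compound 1 to compound 2 (0.13 log units; within the scatter), exchanged one halophenyl for another on an amide-type nitrogen and stayed within the scatter, so an exchange of halophenyls here is expected to give no step beyond the scatter either, as a 1.0-fold lower number from compound 3 to compound 4 (0.02 log units; within the scatter). For compound 4 the estimate in this assay is 25000 nM, expected to fall between 10000 nM and 60000 nM.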

Compound 4, half-maximal inhibitory concentration: 11500 nM
Estimate against measurement, compound 4: 2.2-fold (0.34 log units) above; low and high end bracket the measured number.
By their numbers in this assay, from the lowest: compounds 1, 4, 2 and 3 (each within the scatter of the next, the first and the last beyond it).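

In this assay the step on the nitrogen on an aromatic ring, a 2.3-fold lower number from compound 3 to compound 4 (0.36 log units; beyond the scatter), goes beyond the scatter, which the earlier halophenyl exchange on an amide-type nitrogen, a 1.3-fold higher number from compound 1 to compound 2 (0.13 log units; within the scatter), did not. So the choice of halophenyl can register at this nitrogen, although 2-fluorophenyl and 4-bromophenyl have equal heavy-atom counts. No measured evidence bears on the reason for this step. The change replaces both the halogen and its place in one move, so the compounds shown cannot separate the two. As far as these compounds go, how this nitrogen would respond to a phenyl carrying an amine or a carboxylic acid also stays open.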